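The compounds below may be only part of what the source reports. "The series", "measured", "known", "first", "only" and "open" are said of these compounds alone.

Of the compounds shown here, two have so far been measured in an assay on isolated protein for inhibition of DNA topoisomerase 1 (Homo sapiens), with a stated time of 30 min, tested at 100 uM; a higher number here means a stronger effect of the compound at the concentration tested, a lower number a weaker effect. Compound 1 `Oc1ccc(-c2cc(-c3ccncc3)nc(-c3cccc(Cl)c3)c2)cc1` gives 29.2%, and compound 2 `Oc1ccc(-c2cc(-c3ccsc3)nc(-c3cccc(Cl)c3)c2)cc1` gives 26%. The two sit together, since the step of a number 3.2 percentage points lower from compound 1 to compound 2 (within the scatter) lies within the scatter. Compound 3 `Oc1ccc(-c2cc(-c3ccncc3)nc(-c3ccc(Cl)cc3)c2)cc1` is the next to be tested; its change from compound 1 is 4-chlorophenyl in place of 3-chlorophenyl on an aromatic carbon. Within the data shown here, no measured step touches the 3-chlorophenyl group: the one step known moved a different group and stayed within the scatter. A step of a number 0.2 percentage points lower from compound 1 to compound 3 (within the scatter) is therefore expected, none beyond the scatter. Compound 3 is estimated at 29%, between 15% and 45%.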

Compound 3, a percentage reported as inhibition, at one concentration (the size of the read-out at that concentration, not a potency): 5.9%
The estimate for compound 3 lay 23.1 percentage points above the measured number; measured number outside the range, below it.
By their numbers in this assay, from the lowest: compound 3; then compounds 2 and 1 (each within the scatter of the next).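

Shifting the chlorine on this ring, with the same atoms in the group, is enough to change the result: in this assay, 4-chlorophenyl in place of 3-chlorophenyl gives a number 23.3 percentage points lower from compound 1 to compound 3 (beyond the scatter). The one earlier step, at the pyridin-4-yl group, stayed within the scatter, so this is the first change shown to go beyond it. Nothing available explains why the chlorine's position matters here.

The compounds shown leave open how a plain phenyl group, or a methoxy group or an amine in place of the chlorine, would behave at this position. They also leave open whether the same drop would appear with thiophen-3-yl in place of pyridin-4-yl.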